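The source may report more compounds than this note shows. Statements on the series, on what has been measured and on what is new or still open speak of the compounds shown alone.

Three compounds have so far been tested in a functional assay on the whole organism (Tail, strain ICR) with Mus musculus as the target, in the tail flick test, with a stated time of 150 min, at a dose of 25 umol/kg by the oral route; a higher number here means a stronger effect of the compound at the dose given, a lower number a weaker effect:

Compound 1, `O=C(CN(c1ncnc2c1ncn2C1CCCCO1)C1CC1)NCC(=O)OCc1ccccc1`: compound 1 gives 7.26%
Compound 2, `CC[C@H](C)[C@H](NC(=O)CN(c1ncnc2c1ncn2C1CCCCO1)C1CC1)C(=O)OCc1ccccc1`: compound 2 gives 16.4%
Compound 3, `C[C@H](NC(=O)CN(c1ncnc2c1ncn2C1CCCCO1)C1CC1)C(=O)OCc1ccccc1`: compound 3 gives 6.01%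

Compound 3 has the lowest of the three numbers in this assay. Its gap to compound 1 is small, as a number 1.3 percentage points lower from compound 1 to compound 3 (within the scatter) shows, while the gap to compound 2, seen as a number 10.4 percentage points lower from compound 2 to compound 3 (beyond the scatter), is real though modest.

Compound 4, `CC(C)(C)OC(=O)NCCCC[C@H](NC(=O)CN(c1ncnc2c1ncn2C1CCCCO1)C1CC1)C(=O)OCc1ccccc1`, differs from compound 3 in one place: 3-((tert-butoxycarbonyl)amino)propyl in place of hydrogen on a saturated chain carbon, two bonds along the chain from an amide-type nitrogen and a carbonyl carbon. The measured steps that bear on this all change the same chain carbon. Going from hydrogen to methyl gave a number 1.3 percentage points lower from compound 1 to compound 3 (within the scatter), from hydrogen to sec-butyl gave a number 9.1 percentage points higher from compound 1 to compound 2 (within the scatter), and from sec-butyl back to methyl gave a number 10.4 percentage points lower from compound 2 to compound 3 (beyond the scatter). A longer group on this carbon has thus gone with a somewhat higher number, but only just beyond the scatter. A step of about a number 6 percentage points higher from compound 3 to compound 4 (within the scatter) is therefore expected, upward if anything. Compound 4 is estimated at 12%, with a likely range from 3% to 25%.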

Compound 4, a percentage reported as activity, at one dose (the size of the read-out at that dose, not a potency): 17.2%
Estimate against measurement, compound 4: 5.2 percentage points below; the range from low to high includes it.
By their numbers in this assay, from the lowest: compounds 3, 1, 2 and 4 (each within the scatter of the next, the first and the last beyond it).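

Replacing methyl with 4-((tert-butoxycarbonyl)amino)butyl on this chain carbon gives a number 11.2 percentage points higher from compound 3 to compound 4 (beyond the scatter) in this assay, so this carbon accepts a long chain carrying nitrogen and oxygen atoms with no loss of effect. That chain offers no clear gain over a branched group, however: the comparison with sec-butyl reads a number 0.8 percentage points higher from compound 2 to compound 4 (within the scatter) and the comparison with hydrogen reads a number 9.9 percentage points higher from compound 1 to compound 4 (within the scatter) as well, so only compound 3 stands clearly apart from compound 4. Nothing measured here bears on what lies behind these steps.

The compounds shown leave open whether the tert-butoxycarbonyl part matters or the chain alone does, which a plain butyl chain or a free amine at the chain end could separate. They also leave open how a carboxylic acid at the end of this chain would compare.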